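Swapping the Naphthyl Tail for a Methoxyphenyl

The source may hold more compounds than are shown below. What is called first, only, known or untested is meant among the compounds shown, and "the series" means these compounds.

Compound 1 `O=S(=O)(NCCCNCc1ccc(Cl)c(Cl)c1)c1cc(C(F)(F)F)cc(C(F)(F)F)c1`: 1500 nM
Compound 2 `O=S(=O)(NCCCNCc1ccc(Cl)c(C(F)(F)F)c1)c1cc(C(F)(F)F)cc(C(F)(F)F)c1`: 5900 nM
Compound 3 `O=S(=O)(NCCCNCc1cccc2ccccc12)c1cc(C(F)(F)F)cc(C(F)(F)F)c1`: 3100 nM

In a functional assay on A2780 cells (Homo sapiens) for inhibition, read by MTT assay, with a stated time of 72 h (a higher number here means a weaker inhibitor of growth, a lower number a stronger inhibitor of growth), compound 3 gives the second highest of the three numbers: a 2.1-fold higher number from compound 1 to compound 3 (0.32 log units; beyond the scatter), whereas a 1.9-fold lower number from compound 2 to compound 3 (0.28 log units; within the scatter). Compound 4 `COc1cccc(CNCCCNS(=O)(=O)c2cc(C(F)(F)F)cc(C(F)(F)F)c2)c1` carries one change, (3-methoxyphenyl in place of naphthalen-1-yl on a saturated chain carbon bound to an amine nitrogen). Among the compounds with values here, the steps that bear on it are the two earlier swaps of this same aryl tail, a 2.1-fold higher number from compound 1 to compound 3 (0.32 log units; beyond the scatter) and a 1.9-fold lower number from compound 2 to compound 3 (0.28 log units; within the scatter), both modest or within the scatter. A further swap of the tail is therefore expected to shift this assay only a little, if at all, in either direction, a 1.3-fold higher number from compound 3 to compound 4 (0.11 log units; within the scatter). Compound 4 is estimated at 4000 nM, with a likely range from 1500 nM to 11000 nM.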

Compound 4, concentration for 50% growth inhibition: 1600 nM
The estimate for compound 4 lay 2.5-fold (0.40 log units) above the measured number; the measured number falls inside the stated range.
By their numbers in this assay, from the lowest: compounds 1, 4, 3 and 2 (each within the scatter of the next, the first and the last beyond it).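

In this assay, a tail with one aromatic ring holds up: replacing naphthalen-1-yl with 3-methoxyphenyl gives a 1.9-fold lower number from compound 3 to compound 4 (0.29 log units; within the scatter). Chlorine is not required here either, as 3-methoxyphenyl in place of 3,4-dichlorophenyl gives a 1.1-fold higher number from compound 1 to compound 4 (0.03 log units; within the scatter), whereas the replacement of 4-chloro-3-(trifluoromethyl)phenyl gives a 3.7-fold lower number from compound 2 to compound 4 (0.57 log units; beyond the scatter), the only one of these steps beyond the scatter. No measurement shown explains these steps.

As far as these compounds go, whether the methoxy group itself matters remains open, and a plain phenyl tail would test that. A pyridin-3-yl tail would show whether the tail's ring must be carbon only.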